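The source may report more compounds than this note shows. Statements on the series, on what has been measured and on what is new or still open speak of the compounds shown alone.

Three compounds of the series have been run in an ADME assay on microsomes from liver (Mus musculus) for metabolic stability, read by LC-MS, with a stated time of 10 min; a lower number here means that less of the compound is left, a higher number that more of the compound is left. Compound 1 `CN(C[C@H]1Cc2c(cccc2N2CCNC(C)(C)C2)CN1)[C@H]1CCCc2cccnc21` gives 44%; compound 2 `CC(C)N1CCN(c2cccc3c2C[C@H](CN(C)[C@H]2CCCc4cccnc42)NC3)CC1` gives 15.1%; compound 3 `FC1(F)CCC(CN(C[C@H]2Cc3c(cccc3N3CCNCC3)CN2)[C@H]2CCCc3cccnc32)CC1` gives 76.6%. For the measured compounds named here, the only step measured so far, a number 28.9 percentage points lower from compound 1 to compound 2 (beyond the scatter), concerns a change on the aromatic carbon and does not touch the amine side. Compound 3 stands highest of the three numbers, beyond the scatter from both compound 1 and compound 2.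

Compound 4 `CN(C[C@H]1Cc2c(cccc2N2CCNCC2)CN1)[C@H]1CCCc2cccnc21` has not yet been run. It differs from compound 3 by hydrogen in place of 4,4-difluorocyclohexyl on a saturated chain carbon bound to an amine nitrogen. Going by the values given here, no measured step matches this change, so the expectation rests on compound 1, which shares the methyl on the amine and gives 44%. A downward step is therefore expected, a number 36.6 percentage points lower from compound 3 to compound 4 (beyond the scatter), and for compound 4 the estimate is 40%, within 20% to 62%.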

Compound 4, percent of the compound remaining: 19.9%
Estimate against measurement, compound 4: 20.1 percentage points above; measured number below the stated range.
By their numbers in this assay, from the lowest: compounds 2 and 4 (each within the scatter of the next); then compound 1; then compound 3.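

In this assay, the change from (4,4-difluorocyclohexyl)methyl to methyl on the amine gives the largest step in the series (a number 56.7 percentage points lower from compound 3 to compound 4 (beyond the scatter)), so this position moves the number further than either change on the aromatic carbon shown here. On the aromatic carbon, 3,3-dimethylpiperazin-1-yl stands apart from piperazin-1-yl (a number 24.1 percentage points lower from compound 1 to compound 4 (beyond the scatter)), while isopropyl and hydrogen on the ring amine nitrogen do not separate (a number 4.8 percentage points higher from compound 2 to compound 4 (within the scatter)). No measurement at hand accounts for these steps. The compounds shown leave open whether the higher number of compound 3 follows the two fluorines or the carbon ring, which a plain cyclohexylmethyl on that amine nitrogen would separate.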